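Replacing the aryl group on the shared core

The source may report more compounds than this note shows. Statements on the series, on what has been measured and on what is new or still open speak of the compounds shown alone.

Measured compounds:
compound 1 `O=C1O[C@H]([C@@H](O)Cn2cc(-c3ccc(Br)cc3)nn2)C(OCc2ccccc2)=C1OCc1ccccc1` — 750 nM
compound 2 `O=C1O[C@H]([C@@H](O)Cn2cc(CNS(=O)(=O)c3ccc(F)cc3)nn2)C(OCc2ccccc2)=C1OCc1ccccc1` — 22500 nM

In a functional assay on A549 cells (Homo sapiens) for antiproliferative activity, read by MTT assay, with a stated time of 72 h (a higher number here means a weaker inhibitor, a lower number a stronger inhibitor), compound 1 gives the lowest of the two numbers; its nearest neighbour is compound 2, and the step of a 30-fold higher number from compound 1 to compound 2 (1.48 log units; beyond the scatter) shows how much the series loses when the aromatic ring on the five-membered aromatic ring with 3 nitrogen is exchanged for the sulfonyl-bearing chain. Compound 3 `C[Si](C)(C)c1cn(C[C@H](O)[C@H]2OC(=O)C(OCc3ccccc3)=C2OCc2ccccc2)nn1` is not yet measured in this assay; it differs from compound 1 by a group of 4 heavy atoms (3 carbon, 1 silicon; no ring) in place of a group of 7 heavy atoms (6 carbon, 1 bromine; one six-membered aromatic ring of carbon only), on an aromatic carbon. Among the compounds with values here, only the step from compound 1 to compound 2 bears on this change, and it is large; compound 3 likewise gives up the six-membered aromatic ring of carbon only, but what enters is a smaller group without ring and without donors or acceptors, so the step from compound 1 to compound 3 is expected to run in the same direction, beyond the scatter, yet smaller than a 30-fold higher number from compound 1 to compound 2 (1.48 log units; beyond the scatter). The estimated step is a 5.3-fold higher number from compound 1 to compound 3 (0.73 log units; beyond the scatter). Compound 3 is therefore expected to give about 4000 nM in this assay, within 1500 nM to 12000 nM.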

Compound 3, half-maximal inhibitory concentration: 19200 nM
Compound 3: middle estimate off by 4.8-fold (0.68 log units), on the low side; measured number outside the range, above it.
By their numbers in this assay, from the lowest: compound 1; then compounds 3 and 2 (each within the scatter of the next).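

In this assay, a large loss at this aromatic carbon does not depend on the sulfonyl-bearing chain: the small silicon-bearing group, with no ring, no donors and no acceptors, also gives a 26-fold higher number from compound 1 to compound 3 (1.41 log units; beyond the scatter). The replacements in compound 2 and compound 3 cannot be told apart, with a 1.2-fold lower number from compound 2 to compound 3 (0.07 log units; within the scatter), although the group in compound 2 carries a six-membered aromatic ring of carbon only and the group in compound 3 has no ring, so among these three compounds only the 4-bromophenyl of compound 1 gives the low number. Nothing available explains this pattern.

As far as these compounds go, it remains open whether a plain phenyl or a 4-chlorophenyl on this carbon would keep the number of compound 1. From the compounds shown here alone, it is equally open whether a tert-butyl group, the all-carbon counterpart of the group in compound 3, would match compound 3.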